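Halogen swap on the aryl ring of a hydrazone series

The source may hold more compounds than are shown below. What is called first, only, known or untested is meant among the compounds shown, and "the series" means these compounds.

Compound 1 `Clc1ccc(-c2csc(N/N=C/c3ccccc3)n2)cc1` and compound 2 `Fc1ccc(-c2csc(N/N=C/c3ccc(Cl)cc3)n2)cc1` share the same core. In an in vitro assay on BTI-TN-5B1-4 cells for inhibition of Amine oxidase [flavin-containing] A (Homo sapiens), read by fluorescence, with a stated time of 15 min, tested at 100 uM (on this read-out lower numbers stand for less inhibition and higher numbers for more inhibition at the one concentration tested (going by the name of the read-out)), compound 1 gives 40%. In this assay compound 2 gives 40%, level with compound 1 at the digits shown and with no change beyond the scatter, so compound 2 stands alongside compound 1 on the numbers available. Compound 3 `Clc1ccc(/C=N/Nc2nc(-c3ccc(Cl)cc3)cs2)cc1` has not yet been measured. It differs from compound 2 by chloro in place of fluoro on an aromatic carbon; the same change, cut one bond further out, reads 4-fluorophenyl to 4-chlorophenyl. For the measured compounds named here, no step between measured compounds covers this change, and the two measured values lie within the scatter of each other. The step of no change at the digits printed from compound 2 to compound 3 (within the scatter) in this assay is therefore expected to be none beyond the scatter. Compound 3 is expected to give 40% in this assay, within a range from 25% to 55%.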

Compound 3, a percentage reported as inhibition, at one concentration (the size of the read-out at that concentration, not a potency): 40%
Compound 3: the middle estimate sits on the measured number at the digits printed; the measured number falls inside the stated range.
By their numbers in this assay, from the lowest: compounds 1, 2 and 3 (each within the scatter of the next).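

In this assay, for the compounds shown here, chloro in place of fluoro on an aromatic carbon, para to a large group, gives no change at the digits printed from compound 2 to compound 3 (within the scatter); this is the first reading of a single change at this position, since compound 1 and compound 2 differ in more than one place. Chloro in place of hydrogen on an aromatic carbon gives no change at the digits printed from compound 1 to compound 3 (within the scatter), so neither single-atom exchange moves the read-out beyond the scatter in this series. Nothing available bears on why these steps are so small.

Open, from the compounds shown here alone, is whether a group other than a halogen at the position para to the large group, such as an amine or a carboxylic acid, would shift the read-out beyond the scatter. Also open, going by these compounds, is whether compounds that read level at the single tested concentration would separate in a full potency measurement.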